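Cytotoxicity Expectation for a Pentafluorophenylsulfonyl Azetidine Amide

The source may hold more compounds than are shown below. What is called first, only, known or untested is meant among the compounds shown, and "the series" means these compounds.

Three compounds from one series share an azetidine amide core bearing a pentafluorophenylsulfonyl group. Compound 1 `O=C(NO)c1ccc(N(Cc2ccc(C3CCCC3)cc2)C(=O)[C@H]2CCN2S(=O)(=O)c2c(F)c(F)c(F)c(F)c2F)cc1` carries a hydroxamic acid; in an ADME assay on MCF-10A cells (Homo sapiens) for cytotoxicity, with a stated time of 72 h (a higher number here means that more compound is needed for the effect, a lower number that less compound is needed), compound 1 gives 7300 nM. Compound 2 `CONC(=O)c1ccc(N(Cc2ccc(C3CCCCC3)cn2)C(=O)[C@H]2CCN2S(=O)(=O)c2c(F)c(F)c(F)c(F)c2F)cc1O` and compound 3 `O=C([C@H]1CCN1S(=O)(=O)c1c(F)c(F)c(F)c(F)c1F)N(Cc1cnc(C2CCCCC2)cn1)c1ccc2c(=O)[nH]ncc2c1` were both entered into this assay, but neither returned a result: in this assay compound 2 gives "not determined" (no result reported), and compound 3 gives "not determined" (no result reported), so compound 2 stands without any number at all, and compound 3 is in the same position. Among the compounds with values here, no comparison between measured compounds can be drawn from these three alone.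

Compound 4 `O=C([C@H]1CCN1S(=O)(=O)c1c(F)c(F)c(F)c(F)c1F)N(Cc1ccc(C2CCCCC2)cn1)c1ccc2c(=O)[nH]cnc2c1` differs from compound 2 in one place, on the amide-type nitrogen: a group of 11 heavy atoms (8 carbon, 2 nitrogen, 1 oxygen; one six-membered aromatic ring of carbon only, one six-membered aromatic ring with 2 hetero atoms) in place of a group of 12 heavy atoms (8 carbon, 1 nitrogen, 3 oxygen; one six-membered aromatic ring of carbon only), on an amide-type nitrogen. Within the data shown here, with no value for compound 2 and no step between measured compounds, the size and direction of this change in this assay cannot be taken from the data; the only anchor is the single reading of compound 1. Compound 4 is therefore expected to sit near that reading, with an estimate of 8000 nM and a range from 2000 nM to 30000 nM.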

Compound 4, half-maximal effective concentration: 4000 nM
Compound 4: the middle estimate sits 2.0-fold (0.30 log units) above what was measured; measured number inside the range.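

Within the data shown here, the result for compound 4 yields no new step, as compound 2 has no single number to set against it in this assay. What the change of group on the amide-type nitrogen does in this assay stays open, and nothing shown offers an explanation for the reading of compound 4.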